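Methoxy added to a urea phenyl: expected effect

The source may hold more compounds than are shown below. What is called first, only, known or untested is meant among the compounds shown, and "the series" means these compounds.

Measured so far in a functional assay on MDA-MB-231 cells (Homo sapiens) for inhibition, with a stated time of 72 h; on this read-out lower numbers stand for stronger inhibition and higher numbers for weaker inhibition:
- compound 1 `COc1ccc(NC(=O)Nc2nc(Nc3cc(OC)cc(OC)c3)cc(Sc3c[nH]c4ccccc34)n2)cc1` gives 9460 nM
- compound 2 `O=C(Nc1ccccc1)Nc1nc(Sc2c[nH]c3ccccc23)cc(N2CCCC2)n1` gives 7890 nM

Both numbers are high, so both compounds inhibit only weakly. Compound 2 has the lower of the two numbers, but its gap to compound 1 lies within the scatter, so the two cannot be told apart on this read-out.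

Compound 3 `COc1ccc(NC(=O)Nc2nc(Sc3c[nH]c4ccccc34)cc(N3CCCC3)n2)cc1` has not been measured. It differs from compound 2 in a single place: methoxy in place of hydrogen on an aromatic carbon. Within the data shown here, no measured pair isolates this change. Among the measured compounds shown here, the only hint comes from compound 1, which already carries a methoxy group on its urea phenyl together with a different group elsewhere, and in this assay compound 1 gives 9460 nM, close to what compound 2 gives at 7890 nM. That closeness gives no sign that this methoxy group moves the read-out much. The step of a 1.1-fold lower number from compound 2 to compound 3 (0.02 log units; within the scatter) is therefore expected to be small, within the scatter, with no firm direction. Compound 3 is estimated at 7500 nM, with a range from 2500 nM to 22000 nM.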

Compound 3, half-maximal inhibitory concentration: 13100 nM
Compound 3: the middle estimate sits 1.7-fold (0.24 log units) below what was measured; the measured number falls inside the stated range.
By their numbers in this assay, from the lowest: compounds 2, 1 and 3 (each within the scatter of the next).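

In this assay, the methoxy group on the urea phenyl, para to a large group, can now be judged from a pair that differs only in this place: the step is a 1.7-fold higher number from compound 2 to compound 3 (0.22 log units; within the scatter) and so phenyl and 4-methoxyphenyl cannot be told apart on this read-out. The second pair keeps the (4-methoxyphenyl)carbamoyl group and has pyrrolidin-1-yl in place of (3,5-dimethoxyphenyl)amino on the core; its step is a 1.4-fold higher number from compound 1 to compound 3 (0.14 log units; within the scatter) and so this exchange, too, gives no separable difference, even though the two groups are quite unlike in size. Nothing available offers an explanation for either step.

Among these compounds, all three compounds give high numbers, so these pairs show only that neither change lifts the compounds clear of the scatter, and they say nothing about groups of another kind on this ring. As far as these compounds go, whether a carboxylic acid or an amine at this same place on the urea phenyl, or a longer chain in place of pyrrolidin-1-yl, would move the read-out beyond the scatter remains open.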